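Swapping a chlorinated benzyl for a thiophene methyl group

A few compounds are considered here, and "the series" means these few. Any claim that something is new, unique, unknown or untested is made for them only; others in the source may bear on it.

Of the compounds shown here, two with the shared core have been measured in an assay on CHO cells for displacement of a labelled ligand from melanin-concentrating hormone receptor 1 (Homo sapiens), read by scintillation counting, with a stated time of 1 h; a higher number here means a weaker inhibitor, a lower number a stronger inhibitor. Compound 1 `CCc1nc2ccc(-n3ccc(OCc4ccc(F)cc4)cc3=O)cc2n1C` gives 48 nM. Compound 2 `Cn1c(C2CC2)nc2ccc(-n3ccc(OCc4ccccc4Cl)cc3=O)cc21` gives 160 nM, the highest of the two numbers and beyond the scatter from compound 1. Compound 3 `Cn1c(C2CC2)nc2ccc(-n3ccc(OCc4cc(C(F)(F)F)cs4)cc3=O)cc21` has not yet been measured; it differs from compound 2 by 4-(trifluoromethyl)thiophen-2-yl in place of 2-chlorophenyl on a saturated chain carbon bound to an oxygen on an aromatic ring. Within the data shown here, no measured pair isolates this change, so the expected step of a 1.3-fold lower number from compound 2 to compound 3 (0.12 log units; within the scatter) in this assay is small, with either direction possible and likely within or near the scatter. Compound 3 is estimated at 120 nM, with a range from 40 nM to 400 nM.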

Compound 3, half-maximal inhibitory concentration: 34 nM
For compound 3 the middle estimate is 3.5-fold (0.55 log units) above the measured one; the whole stated range lies above it.
By their numbers in this assay, from the lowest: compounds 3 and 1 (each within the scatter of the next); then compound 2.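

In this assay the swap of 2-chlorophenyl for 4-(trifluoromethyl)thiophen-2-yl gives a 4.7-fold lower number from compound 2 to compound 3 (0.67 log units; beyond the scatter) and shows that the group on this saturated chain carbon can set the number. The position accepts a five-membered aromatic ring in place of the six-membered one without any loss. No measurement available here accounts for the size of this step.

On these data alone, the ring and its substituent change together, so their separate shares remain unknown. A plain thiophen-2-yl or a 3-(trifluoromethyl)phenyl group at this position would help to separate them.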